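Trimming a Side Chain: From Compound 1 to Compound 3

The source may hold more compounds than are shown below. What is called first, only, known or untested is meant among the compounds shown, and "the series" means these compounds.

Measured compounds:
- compound 1, `CCCCNC(=O)N1CC1C#N`: 12000 nM
- compound 2, `N#CC1CN1C(=O)Nc1ccc([N+](=O)[O-])cc1`: 2600 nM

Two compounds share a small core carrying a nitrile and a urea. In a functional assay on L1210 cells (Mus musculus) for inhibition, read by MTT assay (on this read-out lower numbers stand for stronger inhibition and higher numbers for weaker inhibition), compound 1 gives 12000 nM, the higher of the two numbers, so it is the weaker inhibitor; compound 2 gives 2600 nM, and this gap lies beyond the usual scatter. The two differ in more than one place, so nothing more is drawn from that pair.

Compound 3, `CCNC(=O)N1CC1C#N`, has not yet been tested. It differs from compound 1 in one spot: hydrogen in place of ethyl on a saturated chain carbon, two bonds along the chain from an amide-type nitrogen. The urea and the nitrile are untouched; only the chain on the urea nitrogen becomes shorter.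

Among the measured compounds shown here, no measured pair shows what shortening this chain does, so the expectation rests on compound 1 alone. A step of this kind is expected to be small, no larger than the scatter, in either direction. Compound 3 is therefore estimated at 15000 nM, within 5000 nM to 45000 nM, which means an expected step of a 1.3-fold higher number from compound 1 to compound 3 (0.10 log units; within the scatter).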

Compound 3, half-maximal inhibitory concentration: 14000 nM
Compound 3: middle estimate off by 1.1-fold (0.03 log units), on the high side; the range from low to high includes it.
By their numbers in this assay, from the lowest: compound 2; then compounds 1 and 3 (each within the scatter of the next).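

In this assay, putting hydrogen in place of ethyl on a saturated chain carbon, two bonds along the chain from an amide-type nitrogen, gives a 1.2-fold higher number from compound 1 to compound 3 (0.07 log units; within the scatter), so a butyl chain and an ethyl chain on the urea cannot be told apart on this read-out. Among the compounds shown here, this is the first pair that differs in one place only, and it shows that the outer part of the butyl chain can go without moving the number beyond the scatter. No supporting data are available to explain this result.

On these data alone, whether the same holds for a much longer chain, such as octyl, or for a chain ending in an amine or a carboxylic acid remains open. It is also unknown what a methyl group alone on the urea nitrogen would do.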